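Series notes: aryl swap on the saturated ring carbon

The compounds below may be only part of what the source reports. "The series", "measured", "known", "first", "only" and "open" are said of these compounds alone.

Of the compounds shown here, three on the shared core have numbers so far. Compound 1 `CC(=O)Oc1ccc(N2C(=O)/C(=C/N3N=C(c4ccccc4)CC3c3ccccc3O)SC2=S)cc1` gives 9400 nM in a functional assay on HL-60 cells (Homo sapiens) for antiproliferative activity, read by MTT assay, with a stated time of 72 h; on this read-out higher numbers stand for weaker inhibition and lower numbers for stronger inhibition. Compound 2 `CCN1C(=O)/C(=C/N2N=C(c3ccccc3)CC2c2ccccc2O)SC1=S` reaches only a limit in this assay, reported as > 10000 nM. Compound 3 `CC(=O)Oc1ccc(N2C(=O)/C(=C/N3N=C(c4ccc5ccccc5c4)CC3c3ccccc3O)SC2=S)cc1` gives 500 nM in this assay and holds the lowest of the two numbers; its nearest value is that of compound 1, the step being a 19-fold lower number from compound 1 to compound 3 (1.27 log units; beyond the scatter). The other measured step, an at least 1.0-fold higher number from compound 1 to compound 2 (0.02 log units; that floor lies within the scatter), sits at the floor described by the limit of > 10000 nM in this assay, at which 1 of the 3 values shown sits.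

Compound 4 `COc1ccc(C2CC(c3ccc4ccccc4c3)=NN2/C=C2\SC(=S)N(c3ccc(OC(C)=O)cc3)C2=O)cc1` differs from compound 3 by 4-methoxyphenyl in place of 2-hydroxyphenyl on a saturated ring carbon. Neither measured step touches this saturated ring carbon: one alters the group on the amide-type nitrogen, the other the group on the carbon with a double bond to nitrogen. Among the compounds with values here, no measured step bears on the change, and nothing argues for a shift beyond the scatter in this assay in either direction. The expected step is accordingly a 1.4-fold higher number from compound 3 to compound 4 (0.15 log units; within the scatter), held with wide bounds. Compound 4 is estimated at 700 nM, between 200 nM and 2500 nM.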

Compound 4, half-maximal inhibitory concentration: > 10000 nM
Compound 4: a limit, no number; the forecaster's own chance of this, stated with the estimate: 5%; middle value at least 14-fold (1.15 log units) away from the limit.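

The saturated ring carbon is not a silent position: in this assay, 4-methoxyphenyl in place of 2-hydroxyphenyl gives an at least 20-fold higher number from compound 3 to compound 4 (1.30 log units; beyond the scatter). Compound 4 keeps the naphthalen-2-yl and 4-acetoxyphenyl groups of compound 3, so these two groups alone do not secure the activity of compound 3, and the aryl group on this carbon matters as well. Compound 4 stands at a limit and not at a number: the limit of > 10000 nM in this assay, at which 2 of the 4 values shown sit.

The change moves the oxygen on the ring and also replaces hydroxy with methoxy, and the compounds shown do not separate these two differences; 2-methoxyphenyl and 4-hydroxyphenyl on this carbon would do so. Also open, going by these compounds, is whether a 2-aminophenyl group here would keep the activity of compound 3.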